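Swapping the Ring-Nitrogen Substituent: Thiocarbamate to Cyclopentyl Amide

The compounds below may be only part of what the source reports. "The series", "measured", "known", "first", "only" and "open" are said of these compounds alone.

Of the compounds shown here, two sharing one core have been measured in a functional assay on isolated protein for inhibition of Glucose-dependent insulinotropic receptor (Rattus norvegicus), read by HTRF and cAMP accumulation; a higher number here means that more compound is needed for the effect, a lower number that less compound is needed. Compound 1 `Cc1nc(S(C)(=O)=O)ccc1Oc1ncnc(OC2CCN(C(=O)O[C@H](C)C(F)(F)F)CC2)c1F` gives 110 nM. For the measured compounds named here, compound 2 `Cc1nc(S(C)(=O)=O)ccc1Oc1ncnc(OC2CCN(C(=S)OC3(C)CC3)CC2)c1F` gives 48.8 nM, the lowest of the two numbers, and the only measured step, a 2.3-fold lower number from compound 1 to compound 2 (0.35 log units; beyond the scatter), shows that exchanging the group on the amine nitrogen in the ring can shift the number modestly.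

Compound 3 `Cc1nc(S(C)(=O)=O)ccc1Oc1ncnc(OC2CCN(C(=O)C3CCCC3)CC2)c1F` carries a further exchange at the same position: a group of 7 heavy atoms (6 carbon, 1 oxygen; one five-membered non-aromatic ring of carbon only) in place of a group of 7 heavy atoms (5 carbon, 1 oxygen, 1 sulfur; one three-membered non-aromatic ring of carbon only), on an amine nitrogen in a ring. Going by the values given here, the earlier step bears on this only loosely, since it concerned a different pair of groups on that nitrogen; no measured step compares a cyclopentylcarbonyl with the group it replaces here. Given that the one available exchange at this position moved the number by a modest amount, a comparably small shift is expected, in this case toward a somewhat higher number, and the step of a 1.6-fold higher number from compound 2 to compound 3 (0.21 log units; within the scatter) is thus estimated to lie near the edge of the usual scatter. The value of compound 3 in this assay is expected to be about 80 nM, with a range from 30 nM to 250 nM.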

Compound 3, half-maximal effective concentration: 407 nM
Compound 3: middle estimate off by 5.1-fold (0.71 log units), on the low side, outside the stated range (above it).
By their numbers in this assay, from the lowest: compound 2; then compound 1; then compound 3.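

In this assay, this position proves more sensitive than the first exchange suggested: with the same count of heavy atoms on the amine nitrogen, replacing the sulfur-containing group of compound 2 with cyclopentylcarbonyl gives an 8.3-fold higher number from compound 2 to compound 3 (0.92 log units; beyond the scatter), a larger step than a 2.3-fold lower number from compound 1 to compound 2 (0.35 log units; beyond the scatter), so the heavy-atom count alone does not set the number. The second comparison keeps the carbonyl and changes only what sits on its carbon, with cyclopentyl in place of 1-(trifluoromethyl)ethoxy, and still gives a 3.7-fold higher number from compound 1 to compound 3 (0.57 log units; beyond the scatter); among these three compounds, the two with an oxygen joining their group to the carbonyl or thiocarbonyl carbon have the lower numbers, and compound 3, with a ring carbon there, has the highest. Nothing available here explains why the number rises in either step.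

Compound 2 differs from compound 3 in both the sulfur and the linking oxygen, so the contribution of each remains unseparated. A 1-methylcyclopropoxy group on an ordinary carbonyl would address the sulfur, while a cyclopentylamino group on the carbonyl would show how a nitrogen link compares with the oxygen and carbon links.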